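The compounds below may be only part of what the source reports. "The series", "measured", "known", "first", "only" and "open" are said of these compounds alone.

Compound 2, `Nc1scc(CN2CCN(c3ccccc3C(F)(F)F)CC2)c1C(=O)c1ccc(Cl)cc1`, is the point of departure. In a functional assay on CHO cells with adenosine receptor A1 (Homo sapiens) as the target, read by cAMP accumulation and immunoassay, with a stated time of 6 min, tested at 0.01 uM (a lower number here means a stronger effect, a higher number a weaker effect of the compound at the concentration tested), compound 2 gives 0%. Compound 3, `Nc1scc(CN2CCC(c3ccc(Cl)cc3)CC2)c1C(=O)c1ccc(Cl)cc1`, gives 0%, so that compound 2 and compound 3 read the same at the digits shown and sit within the scatter of each other. Compound 1, `COc1ccc(N2CCN(Cc3csc(N)c3C(=O)c3ccc(Cl)cc3)CC2)cc1`, gives -1.2%, and the step of a number 1.2 percentage points higher from compound 1 to compound 2 (within the scatter) is likewise within the scatter, so none of the three compounds can be told apart on these numbers.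

Compound 4, `Nc1scc(CN2CCN(c3ccc(F)c(F)c3)CC2)c1C(=O)c1ccc(Cl)cc1`, differs from compound 2 in one place: 3,4-difluorophenyl in place of 2-(trifluoromethyl)phenyl on an amine nitrogen in a ring. Going by the values given here, the only measured step that bears on this change is a number 1.2 percentage points higher from compound 1 to compound 2 (within the scatter), where a different aryl group was swapped on the same ring nitrogen without a change beyond the scatter. Among the compounds with values here, with compound 2 and compound 3 also level, nothing among the measured compounds points to a step beyond the scatter for this change. Compound 4 is therefore expected to give 0%, in a range from -10% to 10%, which means an expected step of no change at the digits printed from compound 2 to compound 4 (within the scatter).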

Compound 4, a percentage reported as activity, at one concentration (the size of the read-out at that concentration, not a potency): -3.2%
Estimate against measurement, compound 4: 3.2 percentage points above; low and high end bracket the measured number.
By their numbers in this assay, from the lowest: compounds 4, 1, 2 and 3 (each within the scatter of the next).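

In this assay the change to 3,4-difluorophenyl on the amine nitrogen in a ring gives a number 3.2 percentage points lower from compound 2 to compound 4 (within the scatter) and also a number 2 percentage points lower from compound 1 to compound 4 (within the scatter). This position has now taken three different substituted phenyl groups, with one, two or three fluorine-free or fluorine-bearing variations among them, and compounds 1, 2 and 4 still cannot be told apart on these numbers. No measurement shown offers an explanation for this result.

All of these read-outs come from a single low concentration, so the compounds shown leave open whether these phenyl groups would differ at any other concentration. Also open, going by these compounds, is what a group of another kind on that ring nitrogen, such as a benzyl group, an acetyl group or a chain ending in a carboxylic acid, would give.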